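Extending the dipropylamino chain of compound 2

This account rests on a few compounds, and the source may have more. Where it says the series, first, only, none or still open, it means among the compounds named here.

Compound 1 `CCCCCCOc1c(-c2cc(OC)c(OC)c(OC)c2)oc2ccccc2c1=O` and compound 2 `CCCN(CCC)CCCOc1c(-c2cc(OC)c(OC)c(OC)c2)oc2ccccc2c1=O` share a core and were both tested in a functional assay on DU-145 cells (Homo sapiens) for antiproliferative activity, read by WST assay, with a stated time of 3 days; a lower number here means a stronger inhibitor, a higher number a weaker inhibitor. Compound 1 gives > 50000 nM, which is a limit of the assay and not a number. Compound 2 gives > 50000 nM, which is likewise only a limit. This leaves compound 2 without a measured potency, and the data hold only (the limit of > 50000 nM in this assay, at which 2 of the 2 values shown sit).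

Compound 3 `CCCN(CCC)CCCCOc1c(-c2cc(OC)c(OC)c(OC)c2)oc2ccccc2c1=O` keeps the core and alters the chain: (dipropylamino)methyl in place of dipropylamino on a saturated chain carbon, three bonds along the chain from an oxygen on an aromatic ring. In other words, 3-(dipropylamino)propyl becomes 4-(dipropylamino)butyl.

Among the measured compounds shown here, the only measured step bearing on this is a step that the two limits leave unreadable from compound 1 to compound 2, and it has no readable size. No particular size or direction is therefore expected in this assay beyond the scatter. The expected change is an at least 1.2-fold lower number from compound 2 to compound 3 (0.09 log units; that floor lies within the scatter). Compound 3 is estimated at 40000 nM, with an expected range of 12000 nM to 60000 nM.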

Compound 3, half-maximal inhibitory concentration: 35800 nM
The estimate for compound 3 lay 1.1-fold (0.05 log units) above the measured number; the range from low to high includes it.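

With 4-(dipropylamino)butyl on the shared core, compound 3 gives 35800 nM in this assay, the only measured number among the compounds shown. Replacing 3-(dipropylamino)propyl with this chain gives an at least 1.3-fold lower number from compound 2 to compound 3 (0.14 log units; that floor lies within the scatter), and the wider comparison gives an at least 1.3-fold lower number from compound 1 to compound 3 (0.14 log units; that floor lies within the scatter). Each step is only a floor, so its true size may be larger, and neither starting compound has a number of its own, only a limit of the assay: the limit of > 50000 nM in this assay, at which 2 of the 3 values shown sit.

As far as these compounds go, whether a longer chain, such as 5-(dipropylamino)pentyl, would move the number in either direction remains open. From the compounds shown here alone, it is also open whether the dipropylamino group itself matters on the butyl chain, which a dimethylamino group or a carboxylic acid in its place would test.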